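The compounds below may be only part of what the source reports. "The series", "measured", "known", "first", "only" and "open" are said of these compounds alone.

Measured so far in a functional assay on NCI-H1299 cells (Homo sapiens) for antiproliferative activity, read by fluorescence and resazurin assay, with a stated time of 48 h; on this read-out higher numbers stand for weaker inhibition and lower numbers for stronger inhibition:

- compound 1 `COc1ccc(Cn2cc(-c3ccc(O)cc3)c(-c3ccc(O)cc3)c2)cc1OC`: 29200 nM
- compound 2 `COc1ccc(-c2cn(Cc3ccc(O)cc3)cc2-c2ccc(OC)c(OC)c2)cc1OC`: 30600 nM
- compound 3 `COc1ccc(-c2cn(Cc3ccc(O)c(O)c3)cc2-c2ccc(OC)cc2)cc1`: 19100 nM

These three compounds share a core and differ in the groups attached to it. Compound 2, at 30600 nM, lies within the usual scatter of compound 1 and of compound 3, so the numbers do not separate the three compounds. The next compound to be tested is compound 4 `COc1ccc(-c2cn(Cc3ccc(O)c(O)c3)cc2-c2ccc(OC)c(OC)c2)cc1OC`. It is compound 2 with a hydroxy in place of hydrogen on an aromatic carbon, ortho to a hydroxy group and meta to a large group. This turns 4-hydroxybenzyl into 3,4-dihydroxybenzyl: hydroxy in place of hydrogen on an aromatic carbon.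

For the measured compounds named here, no two measured compounds differ in only one place, so a change of this kind has not been seen on its own. The nearest guide is compound 3, which also carries 3,4-dihydroxybenzyl but differs from compound 2 elsewhere too. Compound 3 gives 19100 nM, still within the scatter of compound 2, so no change beyond the scatter is expected in this assay. The expected change, a 1.5-fold lower number from compound 2 to compound 4 (0.18 log units; within the scatter), is therefore small. For compound 4 the estimated value is 20000 nM, with an expected range of 8000 nM to 40000 nM.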

Compound 4, half-maximal inhibitory concentration: 23400 nM
Compound 4: middle estimate off by 1.2-fold (0.07 log units), on the low side; the measured number falls inside the stated range.
By their numbers in this assay, from the lowest: compounds 3, 4, 1 and 2 (each within the scatter of the next).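

This is the first pair shown that differs in one place only, so the added hydroxy can now be read on its own: in this assay, turning 4-hydroxybenzyl into 3,4-dihydroxybenzyl gives a 1.3-fold lower number from compound 2 to compound 4 (0.12 log units; within the scatter) on an otherwise unchanged structure. At this place on the aromatic ring, ortho to a hydroxy group and meta to a large group, the new hydroxy therefore brings no difference that this read-out can separate from the scatter of repeated measurements. Nothing available here offers an explanation for this result.

This single step does not show whether a different group at the same place, such as an amine, a carboxylic acid or a longer chain, would move the number beyond the scatter. It also leaves open whether the same hydroxy would behave in the same way when the other groups on the shared core are different, as a single pair of compounds can speak only for its own structures.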